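Core bromo removal after the fluoro-for-bromo step

The compounds below may be only part of what the source reports. "The series", "measured", "known", "first", "only" and "open" are said of these compounds alone.

Within the data shown here, compound 2 `O=c1cc(-n2cc(COc3ccc(F)cc3)nn2)c2cc(Br)ccc2o1` gives 7000 nM in a functional assay on MCF7 cells (Homo sapiens) for antiproliferative activity, read by MTT assay, with a stated time of 48 h (on this read-out higher numbers stand for weaker inhibition and lower numbers for stronger inhibition), the higher of the two numbers so far; compound 1 `O=c1cc(-n2cc(COc3ccc(Br)cc3)nn2)c2cc(Br)ccc2o1` gives 1920 nM in this assay. Compound 3 `O=c1cc(-n2cc(COc3ccc(F)cc3)nn2)c2ccccc2o1` differs from compound 2 by hydrogen in place of bromo on an aromatic carbon, on an aromatic carbon of the six-membered ring of the shared core. Among the measured compounds shown here, no measured step removes this bromo. For the measured compounds named here, the only step in hand, a 3.6-fold higher number from compound 1 to compound 2 (0.56 log units; beyond the scatter), concerns a halogen on the pendant ring, not the core, so it bears on compound 3 only loosely. A modest weakening is expected for compound 3 a 1.7-fold higher number from compound 2 to compound 3 (0.23 log units; within the scatter), with a wide range. Compound 3 is estimated at 12000 nM, between 4000 nM and 35000 nM.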

Compound 3, half-maximal inhibitory concentration: 5840 nM
Estimate against measurement, compound 3: 2.1-fold (0.31 log units) above; measured number inside the range.
By their numbers in this assay, from the lowest: compound 1; then compounds 3 and 2 (each within the scatter of the next).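

In this assay, hydrogen in place of bromo on the shared core gives a 1.2-fold lower number from compound 2 to compound 3 (0.08 log units; within the scatter), so with the fluoro pendant ring, this bromo is not needed to hold the activity of compound 2. Among these compounds, at this stage, the only step beyond the scatter remains the pendant halogen step, a 3.6-fold higher number from compound 1 to compound 2 (0.56 log units; beyond the scatter) on the other ring. No measurement on hand accounts for either result.

From the compounds shown here alone, whether hydrogen is equally well accepted on the core with bromo on the pendant ring stays open. So does the effect of a group such as an amine or a methoxy group at this core position.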